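Trimethoxyphenyl at the enone terminus of the shared core

The compounds below may be only part of what the source reports. "The series", "measured", "known", "first", "only" and "open" are said of these compounds alone.

For the measured compounds named here, compound 2 `COc1cc(-c2cc(C(=O)/C=C/c3ccccc3)nc3cc(-c4ccccc4)nn23)cc(OC)c1OC` gives 18000 nM in a functional assay on A549 cells (Homo sapiens) for antiproliferative activity, read by MTT assay, with a stated time of 24 h (on this read-out lower numbers stand for stronger inhibition and higher numbers for weaker inhibition), the highest of the two numbers so far; compound 1 `COc1ccc(C(=O)/C=C/c2cc(-c3cc(OC)c(OC)c(OC)c3)n3nc(-c4ccccc4)cc3n2)cc1` gives 14600 nM, within the scatter of it. Compound 3 `COc1cc(/C=C/C(=O)c2cc(-c3cc(OC)c(OC)c(OC)c3)n3nc(-c4ccccc4)cc3n2)cc(OC)c1OC` carries 3,4,5-trimethoxyphenyl in place of phenyl on a double-bonded chain carbon bound to a double-bonded chain carbon. Going by the values given here, the only step bearing on this position, a 1.2-fold higher number from compound 1 to compound 2 (0.09 log units; within the scatter), swapped substituents on the same terminal ring and stayed within the scatter, so no change beyond the scatter is expected for compound 3. The estimate for compound 3 in this assay is 15000 nM, with a range of 5000 nM to 45000 nM, meaning an expected step of a 1.2-fold lower number from compound 2 to compound 3 (0.08 log units; within the scatter).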

Compound 3, half-maximal inhibitory concentration: 25900 nM
Compound 3: middle estimate off by 1.7-fold (0.24 log units), on the low side, and the stated range covers the measured number.
By their numbers in this assay, from the lowest: compounds 1, 2 and 3 (each within the scatter of the next).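

In this assay, 3,4,5-trimethoxyphenyl in place of phenyl on a double-bonded chain carbon bound to a double-bonded chain carbon gives a 1.4-fold higher number from compound 2 to compound 3 (0.16 log units; within the scatter) and so adds the first direct read at this position. Going from 6 to 12 heavy atoms and from 0 to 3 hydrogen-bond acceptors here leaves the two numbers within the scatter of each other. No measurement at hand accounts for this result.

From the compounds shown here alone, whether any group at this position moves the number beyond the scatter stays open. An amine or a carboxylic acid on this terminal ring would test that.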